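Swapping Bromo for Cyano at One Aromatic Carbon

The source may report more compounds than this note shows. Statements on the series, on what has been measured and on what is new or still open speak of the compounds shown alone.

Among the compounds with values here, in a functional assay on K562 cells (Homo sapiens) for cytotoxicity, read by MTT assay, with a stated time of 24 h (on this read-out lower numbers stand for stronger inhibition and higher numbers for weaker inhibition), compound 3 (`COc1cc(/C=C2\CN(C)C/C(=C\c3ccc(Br)cc3)C2=O)cc(OC)c1OC`) gives 12400 nM, the higher of the two actual numbers so far. Compound 1 (`COc1cc(/C=C2\CN(C)C/C(=C\c3cc(OC)c(OC)c(OC)c3)C2=O)cc(OC)c1`) gives the lower one (3470 nM). That gap reads as a 3.6-fold higher number from compound 1 to compound 3 (0.55 log units; beyond the scatter), and it came with replacing a whole 3,5-dimethoxyphenyl group. Compound 2 (`COc1cc(/C=C2\CN(C)C/C(=C\c3ccc(Cl)cc3)C2=O)cc(OC)c1OC`) shows only a limit (> 20000 nM).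

Compound 4 (`COc1cc(/C=C2\CN(C)C/C(=C\c3ccc(C#N)cc3)C2=O)cc(OC)c1OC`) carries cyano in place of bromo on an aromatic carbon. The closest measured swap, bromo in place of chloro on an aromatic carbon, gave an at least 1.6-fold lower number from compound 2 to compound 3 (0.20 log units; that floor lies within the scatter), a floor within the scatter. A small swap at this spot is therefore expected to give no step beyond the scatter in this assay, and the expected change is a 1.0-fold higher number from compound 3 to compound 4 (0.02 log units; within the scatter). Compound 4 is estimated at 13000 nM, with an expected range from 6000 nM to 25000 nM.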

Compound 4, half-maximal inhibitory concentration: 4290 nM
The estimate for compound 4 lay 3.0-fold (0.48 log units) above the measured number, and the stated range ends above it.
By their numbers in this assay, from the lowest: compounds 1 and 4 (each within the scatter of the next); then compound 3. At a limit, above all of these: compound 2.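

The swap of bromo for cyano shows that a change at this aromatic carbon can move the number beyond the scatter in this assay: a 2.9-fold lower number from compound 3 to compound 4 (0.46 log units; beyond the scatter). Compound 2 gives only a limit, so its step is a floor: an at least 4.6-fold lower number from compound 2 to compound 4 (0.66 log units; beyond the scatter). With 4-cyanophenyl in place, compound 4 cannot be told apart from compound 1, which carries 3,5-dimethoxyphenyl: a 1.2-fold higher number from compound 1 to compound 4 (0.09 log units; within the scatter).

As far as these compounds go, whether an amine or a carboxylic acid at this carbon would give a lower or higher number stays open. Nothing measured here gives a reason for the step.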